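Series notes: amide variation on a shared pyrazole-fused core

A few compounds are considered here, and "the series" means these few. Any claim that something is new, unique, unknown or untested is made for them only; others in the source may bear on it.

Measured so far in a functional assay on A2780 cells (Homo sapiens) for antiproliferative activity, read by fluorescence, with a stated time of 72 h; a lower number here means a stronger inhibitor, a higher number a weaker inhibitor:
compound 1 `CC(C)(C)C(=O)N1Cc2c(NC(=O)c3ccncc3)n[nH]c2C1(C)C`: 110 nM
compound 2 `CC1(C)c2[nH]nc(NC(=O)c3ccc(F)cc3)c2CN1C(=O)C1CCN(C2CC2)CC1`: 380 nM
compound 3 `CN1CCC(C(=O)N2Cc3c(NC(=O)Nc4cccc(F)c4)n[nH]c3C2(C)C)CC1`: 350 nM

Compound 1 gives the lowest number of the three in this assay; its gaps to compound 3 and to compound 2 both lie beyond the usual scatter, so compound 1 is the strongest inhibitor among them. Compounds 2 and 3 differ from compound 1 in more than one place, so none of the three pairs shows a single-point step.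

The next compound, compound 4 `CN1CCC(C(=O)Nc2n[nH]c3c2CN(C(=O)C(C)(C)C)C3(C)C)CC1`, differs from compound 1 in one place:
1-methylpiperidin-4-yl in place of pyridin-4-yl on a carbonyl carbon

For the measured compounds named here, no measured pair isolates this change. Compounds 2 and 3 carry a piperidine in a different position and also other changes, so their values say nothing direct about it. A saturated, basic ring is a sizeable change from an aromatic one at the amide carbonyl, and some loss relative to compound 1 is expected, likely modest and possibly within the scatter. For compound 4 the estimate in this assay is 250 nM, range 80 nM to 800 nM, which corresponds to an expected step of a 2.3-fold higher number from compound 1 to compound 4 (0.36 log units; beyond the scatter).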

Compound 4, half-maximal inhibitory concentration: 350 nM
Compound 4: the middle estimate sits 1.4-fold (0.15 log units) below what was measured; the measured number falls inside the stated range.
By their numbers in this assay, from the lowest: compound 1; then compounds 3, 4 and 2 (each within the scatter of the next).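

In this assay, this position on the carbonyl carbon now has its first single-point reading: 1-methylpiperidin-4-yl in place of pyridin-4-yl gives a 3.2-fold higher number from compound 1 to compound 4 (0.50 log units; beyond the scatter). The earlier compounds shown here could not show this, as compounds 2 and 3 each differ from compound 1 in more than one place; the step shows that the group here affects the read-out and that the six-membered aromatic ring of compound 1 can be exchanged for a six-membered non-aromatic ring with activity retained, compound 4 giving 350 nM. No measured evidence on hand accounts for the size of this step, so its origin remains unassigned.

One exchange cannot separate the contribution of the ring itself from that of the methyl group it carries, a question that piperidin-4-yl without the methyl group or a plain cyclohexyl at the same carbonyl carbon would address. Nor do the compounds shown tell whether the step would stay the same with another group in place of the pivaloyl amide of compound 1, or how a morpholine would compare at this position.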